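From 3-methylphenyl to 3,5-difluorophenyl on the shared core

The source may hold more compounds than are shown below. What is called first, only, known or untested is meant among the compounds shown, and "the series" means these compounds.

In a functional assay on HCT-116 cells (Homo sapiens) for inhibition, read by MTT assay, with a stated time of 48 h (a higher number here means a weaker inhibitor, a lower number a stronger inhibitor), compound 1 `Cc1nnsc1CO/N=C/c1c(C)nn(C)c1Oc1ccc(F)cc1` gives 30200 nM, compound 2 `Cc1nnsc1CO/N=C/c1c(C)nn(C)c1Oc1ccc(Br)cc1` gives 7190 nM and compound 3 `Cc1cccc(Oc2c(/C=N/OCc3snnc3C)c(C)nn2C)c1` gives 14100 nM. Compound 3 sits close to compound 2, with a 2.0-fold higher number from compound 2 to compound 3 (0.29 log units; within the scatter), and apart from compound 1, with a 2.1-fold lower number from compound 1 to compound 3 (0.33 log units; beyond the scatter). Compound 4 `Cc1nnsc1CO/N=C/c1c(C)nn(C)c1Oc1cc(F)cc(F)c1` differs from compound 3 by 3,5-difluorophenyl in place of 3-methylphenyl on an oxygen on an aromatic ring. Among the measured compounds shown here, compound 1, with its 4-fluorophenyl, is the only measured fluorinated compound, and its steps were modest: a 2.1-fold lower number from compound 1 to compound 3 (0.33 log units; beyond the scatter) and a 4.2-fold lower number from compound 1 to compound 2 (0.62 log units; beyond the scatter). A small rise within the scatter is therefore expected in this assay, the estimated change being a 1.4-fold higher number from compound 3 to compound 4 (0.15 log units; within the scatter). For compound 4 the expected value is 20000 nM, with an estimated range of 8000 nM to 50000 nM.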

Compound 4, half-maximal inhibitory concentration: 8120 nM
The estimate for compound 4 lay 2.5-fold (0.39 log units) above the measured number, and the stated range covers the measured number.
By their numbers in this assay, from the lowest: compounds 2, 4 and 3 (each within the scatter of the next); then compound 1.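

In this assay, 3,5-difluorophenyl in place of 4-fluorophenyl on this oxygen gives a step beyond the scatter (a 3.7-fold lower number from compound 1 to compound 4 (0.57 log units; beyond the scatter)), so a fluorinated phenyl here does not by itself place a compound with compound 1. Compound 4 stays level with its other neighbours (a 1.7-fold lower number from compound 3 to compound 4 (0.24 log units; within the scatter); a 1.1-fold higher number from compound 2 to compound 4 (0.05 log units; within the scatter)), leaving only compound 1 apart. Nothing available explains these differences.

Going by these compounds, whether the step follows the number of fluorines or their places stays open, as a 3-fluorophenyl could help to show. Also open, on these data alone, is how an aminophenyl or a carboxyphenyl would read on this oxygen.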